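Three inactive hydrazones and a dibromohydroxyphenyl newcomer

The source may report more compounds than this note shows. Statements on the series, on what has been measured and on what is new or still open speak of the compounds shown alone.

Compound 3 `O=C(N/N=C/c1ccco1)c1cccc(S(=O)(=O)N2CCOCC2)c1` sits at the edge of what a functional assay on PC-3 cells (Homo sapiens) for antiproliferative activity, read by MTT assay, with a stated time of 72 h (on this read-out higher numbers stand for weaker inhibition and lower numbers for stronger inhibition), can report. In this assay compound 3 gives > 100000 nM, which is a limit of the assay and not a number. Compound 1 `C/C(=N\NC(=O)c1cccc(S(=O)(=O)N2CCOCC2)c1)c1cccc(O)c1` is in the same position: in this assay compound 1 gives > 100000 nM, again a limit. Compound 2 `C/C(=N\NC(=O)c1cccc(S(=O)(=O)N2CCOCC2)c1)c1cc(O)ccc1O` likewise: in this assay compound 2 gives > 100000 nM, also a limit. The only one-place step among these three, a step that the two limits leave unreadable from compound 1 to compound 2, therefore cannot be read, and the whole set is summed up by the limit of > 100000 nM in this assay, at which 3 of the 3 values shown sit.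

Compound 4 `O=C(N/N=C/c1cc(Br)cc(Br)c1O)c1cccc(S(=O)(=O)N2CCOCC2)c1` differs from compound 3 by 3,5-dibromo-2-hydroxyphenyl in place of furan-2-yl on a carbon with a double bond to nitrogen. Among the measured compounds shown here, no measured step touches this exchange of an aromatic group on the carbon with a double bond to nitrogen, and the single step that exists between measured compounds gives no readable size. With all three measured values sitting at the same limit, there is no basis for expecting compound 4 to move beyond the scatter in either direction, although the step is also not one any shown pair has tested. Compound 4 is therefore expected to give 80000 nM in this assay, within 20000 nM to 300000 nM, and the step from compound 3 is estimated as an at least 1.2-fold lower number from compound 3 to compound 4 (0.09 log units; that floor lies within the scatter).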

Compound 4, half-maximal inhibitory concentration: 9700 nM
Compound 4: the middle estimate sits 8.2-fold (0.92 log units) above what was measured, outside the stated range (below it).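

In this assay, among the compounds shown here, the exchange of furan-2-yl for 3,5-dibromo-2-hydroxyphenyl on a carbon with a double bond to nitrogen gives an at least 10-fold lower number from compound 3 to compound 4 (1.01 log units; beyond the scatter), so a change at this place can carry the series into a readable range, which the earlier compounds could not show. Compound 4 gives 9700 nM and is the only compound shown with a number instead of a limit of the assay: the limit of > 100000 nM in this assay, at which 3 of the 4 values shown sit. The exchange replaces the whole aromatic group in one step, with a five-membered ring leaving and a six-membered ring bearing bromine and hydroxy entering, so this single step cannot be divided among the ring, the bromine atoms and the hydroxy.

What the compounds shown leave open is which of these parts carries the step, as a plain phenyl, a 2-hydroxyphenyl without bromine or a chlorine-bearing counterpart at the same carbon would be needed to separate them. From the compounds shown here alone, it also remains open whether the shared core would tolerate an amine or a carboxylic acid in place of its other groups while the 3,5-dibromo-2-hydroxyphenyl stays in position.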